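The compounds below may be only part of what the source reports. "The series", "measured", "known", "first", "only" and "open" are said of these compounds alone.

Measured in a functional assay on A2780 cells (Homo sapiens) for antiproliferative activity, read by fluorescence, with a stated time of 72 h (a higher number here means a weaker inhibitor, a lower number a stronger inhibitor), are three compounds

Compound 1 `CN1CCC(C(=O)N2Cc3c(NC(=O)C4CCC4)n[nH]c3C2(C)C)CC1` gives 140 nM
Compound 2 `CN1CCC(C(=O)N2Cc3c(NC(=O)c4ccc5ccccc5c4)n[nH]c3C2(C)C)CC1` gives 270 nM
Compound 3 `CN1CCC(C(=O)N2Cc3c(NC(=O)c4ccc(Cl)cc4)n[nH]c3C2(C)C)CC1` gives 120 nM

Compound 3 stands level, within the scatter, with its nearest neighbour (a 1.2-fold lower number from compound 1 to compound 3 (0.07 log units; within the scatter)) and lies modestly clear of the naphthalen-2-yl amide (a 2.3-fold lower number from compound 2 to compound 3 (0.35 log units; beyond the scatter)). Compound 4 `CN1CCC(C(=O)N2Cc3c(NC(=O)c4ccco4)n[nH]c3C2(C)C)CC1` is not yet measured and differs from it in one place (furan-2-yl in place of 4-chlorophenyl on a carbonyl carbon), with furan-2-yl in place of 4-chlorophenyl on a carbonyl carbon. Among the measured compounds shown here, no measured compound carries furan-2-yl, so the guide is the other swaps on that carbonyl carbon. One more of these also stays within the scatter (a 1.9-fold higher number from compound 1 to compound 2 (0.29 log units; within the scatter)), and only the modest step above passes it. No step beyond the scatter is therefore expected in this assay, in either direction. The expected change is small (a 1.3-fold higher number from compound 3 to compound 4 (0.10 log units; within the scatter)). For compound 4 the estimate is 150 nM, with an expected range of 60 nM to 380 nM.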

Compound 4, half-maximal inhibitory concentration: > 5000 nM
Compound 4 ended at the assay's limit (the forecaster's own chance of this, stated with the estimate: 2%); at least 33-fold (1.52 log units) between middle value and limit.
By their numbers in this assay, from the lowest: compounds 3, 1 and 2 (each within the scatter of the next, the first and the last beyond it). At a limit, above all of these: compound 4.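

In this assay the reading for compound 4 is a limit of the assay and not a number: the limit of > 5000 nM in this assay, at which 1 of the 4 values shown sits. The earlier swaps on this carbonyl carbon gave at most a modest step, whereas furan-2-yl stands far from all three other groups: an at least 41-fold higher number from compound 3 to compound 4 (1.61 log units; beyond the scatter), an at least 18-fold higher number from compound 2 to compound 4 (1.26 log units; beyond the scatter) and an at least 35-fold higher number from compound 1 to compound 4 (1.55 log units; beyond the scatter). The position is therefore not indifferent to the group it carries, and one ring exchange here can take activity to the limit. The compounds shown leave open whether the loss follows the ring oxygen or the five-membered ring itself, which a thiophen-2-yl or an unsubstituted phenyl group on the same carbonyl carbon would help to separate.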